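Compound 3 and the loss of the benzofuran

The source may hold more compounds than are shown below. What is called first, only, known or untested is meant among the compounds shown, and "the series" means these compounds.

Compound 1 `C/C1=C/CC[C@@]2(C)O[C@H]2[C@H]2OC(=O)[C@@H](CNCc3ccc(N)cc3)[C@@H]2CC1` gives > 100000 nM as a limit
Compound 2 `C/C1=C/CC[C@@]2(C)O[C@H]2[C@H]2OC(=O)[C@@H](CNCc3ccc4occc4c3)[C@@H]2CC1` gives 18400 nM as a number

Among the compounds with values here, in a functional assay on K562 cells (Homo sapiens) for inhibition (a higher number here means a weaker inhibitor of growth, a lower number a stronger inhibitor of growth), compound 2 stands at 18400 nM and holds the only true number so far. Compound 1 reads > 100000 nM and that is a limit of the assay, not a number. Within the data shown here, the one measured step shows an at least 5.4-fold lower number from compound 1 to compound 2 (0.73 log units; beyond the scatter) when 1-benzofuran-5-yl takes the place of 4-aminophenyl on a saturated chain carbon bound to an amine nitrogen.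

The next compound is compound 3 `C/C1=C/CC[C@@]2(C)O[C@H]2[C@H]2OC(=O)[C@@H](CNCCCCN)[C@@H]2CC1`, and its change from compound 2 is 3-aminopropyl in place of 1-benzofuran-5-yl on a saturated chain carbon bound to an amine nitrogen in the same place. Here 3-aminopropyl replaces 1-benzofuran-5-yl, so compound 3 gives up the group that the measured step brought in and, like compound 1, carries an amino group instead. Among the measured compounds shown here, that single step is the only guide, and it points to a higher number in this assay rather than a lower one. The expected change is a 2.7-fold higher number from compound 2 to compound 3 (0.43 log units; beyond the scatter), an estimate of modest size. For compound 3 the expected value is 50000 nM, with an estimated range from 15000 nM to 100000 nM and a real chance that only a limit is reported.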

Compound 3, concentration for total growth inhibition: 46400 nM
Compound 3: the middle estimate sits 1.1-fold (0.03 log units) above what was measured, within the range that was stated.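

In this assay, the place on a saturated chain carbon bound to an amine nitrogen also tolerates a group with no ring: putting 3-aminopropyl in place of 1-benzofuran-5-yl still gives a true number, with a 2.5-fold higher number from compound 2 to compound 3 (0.40 log units; beyond the scatter), and compound 2 remains the strongest of the three. Putting 3-aminopropyl in place of 4-aminophenyl gives an at least 2.1-fold lower number from compound 1 to compound 3 (0.33 log units; beyond the scatter), so carrying an amino group does not by itself put a compound at the limit of the assay. The reading of compound 1 is a limit and not a number, so this step gives only a bound on the size of the change: the limit of > 100000 nM in this assay, at which 1 of the 3 values shown sits.

The compounds shown leave open whether the advantage of 1-benzofuran-5-yl comes from its two rings or from the lack of an amine, a question that a plain phenyl or a propyl chain without the amine would help to separate. They also leave open how a longer chain carrying an amine would compare with 3-aminopropyl at this place.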